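Benzyl versus isopropyl on the amine nitrogen

The source may report more compounds than this note shows. Statements on the series, on what has been measured and on what is new or still open speak of the compounds shown alone.

Compound 2 `COc1cc(Oc2cccc(Nc3ccccc3)c2)cc(OC)c1CNC(C)C` stands at the weak end of the measured pair. In a functional assay on HCT-15 cells (Homo sapiens) for inhibition, read by MTT assay, with a stated time of 72 h (a higher number here means a weaker inhibitor, a lower number a stronger inhibitor), compound 2 reaches only the limit > 20000 nM, which is a limit and not a number. Compound 1 `COc1cc(Oc2cccc(Nc3ccccc3)c2)cc(OC)c1CNCc1ccc(F)cc1` carries 4-fluorobenzyl at the same nitrogen, and in this assay compound 1 gives 3640 nM. Within the data shown here, the one measured step that bears on the change is an at least 5.4-fold higher number from compound 1 to compound 2 (0.73 log units; beyond the scatter), a lower bound given (the limit of > 20000 nM in this assay, at which 1 of the 2 values shown sits). Compound 3 `COc1cc(Oc2cccc(Nc3ccccc3)c2)cc(OC)c1CNCc1ccc(O)cc1` reverses it: 4-hydroxybenzyl in place of isopropyl on an amine nitrogen. A drop at least of that order is expected, so the estimated step is an at least 4.4-fold lower number from compound 2 to compound 3 (0.64 log units; beyond the scatter). Compound 3 is expected near 4500 nM (range 1500 nM to 15000 nM).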

Compound 3, half-maximal inhibitory concentration: 3430 nM
Compound 3: middle estimate off by 1.3-fold (0.12 log units), on the high side; measured number inside the range.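

In this assay, the gain over isopropyl seen with 4-fluorobenzyl also appears with 4-hydroxybenzyl on the amine nitrogen (an at least 5.8-fold lower number from compound 2 to compound 3 (0.76 log units; beyond the scatter)). Hydroxy in place of fluoro on an aromatic carbon gives (a 1.1-fold lower number from compound 1 to compound 3 (0.03 log units; within the scatter)), so these two benzyl groups cannot be told apart here. Compound 2 stands at a limit and not at a number: the limit of > 20000 nM in this assay, at which 1 of the 3 values shown sits.

Still open, going by these compounds, is whether an unsubstituted benzyl group or a 4-methoxybenzyl group reads the same. A phenethyl group or a cyclohexylmethyl group would test whether the longer chain or the aromatic ring matters at this nitrogen.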